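A few compounds are considered here, and "the series" means these few. Any claim that something is new, unique, unknown or untested is made for them only; others in the source may bear on it.

Two compounds of the series have numbers in a functional assay on MCF7 cells (Homo sapiens) for cytotoxicity; a lower number here means a stronger inhibitor, a higher number a weaker inhibitor. Compound 1 `Cc1c(N/C=C2\C(=N)N(c3ccccc3)N=C2N)c(=O)n(-c2ccccc2)n1C` gives 60700 nM in this assay. Compound 2 `Cc1c(-n2cc(C#N)c(=O)n(-c3ccc(Br)cc3)c2=S)c(=O)n(-c2ccccc2)n1C` gives 43400 nM in this assay. Compound 2 has the lower of the two numbers, yet the gap to compound 1 is within the usual scatter, so the two cannot be ranked against each other. Compound 3 `Cc1c(-n2cc(C#N)c(=O)n(-c3ccc(I)cc3)c2=S)c(=O)n(-c2ccccc2)n1C` is not yet measured. The change from compound 2 to compound 3 is iodo in place of bromo on an aromatic carbon; the bromo leaves and the iodo enters on an aromatic carbon of the six-membered aromatic ring of carbon only, para to a large group, so that the 4-bromophenyl becomes a 4-iodophenyl. Among the measured compounds shown here, no measured pair isolates such a halogen exchange, so nothing measured speaks for or against a shift in this assay. A step of this kind is expected to stay within the scatter, with no clear direction. Compound 3 is therefore expected to give about 40000 nM in this assay, with a range from 15000 nM to 100000 nM. The step that this estimate means, a 1.1-fold lower number from compound 2 to compound 3 (0.04 log units; within the scatter), is expected to be small.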

Compound 3, half-maximal inhibitory concentration: 30700 nM
Estimate against measurement, compound 3: 1.3-fold (0.11 log units) above; the range from low to high includes it.
By their numbers in this assay, from the lowest: compounds 3, 2 and 1 (each within the scatter of the next).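

In this assay, among the compounds shown here, iodo in place of bromo on an aromatic carbon, para to a large group, gives a 1.4-fold lower number from compound 2 to compound 3 (0.15 log units; within the scatter) as the first step that isolates a change in one place. For the compounds shown here, the 4-bromophenyl and the 4-iodophenyl therefore cannot be told apart in this assay, so this position accepts an exchange of one halogen for the other without a shift beyond the scatter, a point on which the earlier compounds were silent. No measurement on hand bears on why the two halogens read alike here.

A single halogen exchange does not show whether this position matters for the number at all, and an amine, a carboxylic acid or a plain hydrogen on the same aromatic carbon could still move it beyond the scatter. Also open is how much the rest of the shared core contributes, since no step shown touches the nitrile, the thiocarbonyl or the phenyl on the other ring.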